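A few compounds are considered here, and "the series" means these few. Any claim that something is new, unique, unknown or untested is made for them only; others in the source may bear on it.

Going by the values given here, compound 3 `CCc1ccc(N2C(=O)C=CC2OCC(F)(F)F)cc1` gives 7840 nM in a functional assay on MDA-MB-231 cells (Homo sapiens) for inhibition (a higher number here means a weaker inhibitor, a lower number a stronger inhibitor), the second highest of the three numbers measured so far. Compound 1 `O=C1C=CC(OCC(F)(F)F)N1c1ccc(C(F)(F)F)cc1` gives 2300 nM, and compound 2 `Cc1ccc(N2C(=O)C=CC2OCC(F)(F)F)cc1` gives 15800 nM. Compound 4 `O=C1C=CC(OCC(F)(F)F)N1c1ccccc1` differs from compound 3 by hydrogen in place of ethyl on an aromatic carbon, para to a large group. The most closely related measured step is a 2.0-fold lower number from compound 2 to compound 3 (0.30 log units; within the scatter), which lies within the scatter. The steps of a 6.9-fold higher number from compound 1 to compound 2 (0.84 log units; beyond the scatter) and a 3.4-fold higher number from compound 1 to compound 3 (0.53 log units; beyond the scatter) show that a smaller group at this position goes with a higher number, so removing the chain altogether is expected to raise the number further. The expected step is a 2.6-fold higher number from compound 3 to compound 4 (0.41 log units; beyond the scatter). Compound 4 is therefore estimated at 20000 nM, with a range from 7000 nM to 60000 nM.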

Compound 4, half-maximal inhibitory concentration: 15300 nM
Compound 4: the middle estimate sits 1.3-fold (0.12 log units) above what was measured; low and high end bracket the measured number.
By their numbers in this assay, from the lowest: compound 1; then compounds 3, 4 and 2 (each within the scatter of the next).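

In this assay the steps of a 2.0-fold higher number from compound 3 to compound 4 (0.29 log units; within the scatter) and a 1.0-fold lower number from compound 2 to compound 4 (0.01 log units; within the scatter) both lie within the scatter, so at this position on the aromatic ring neither ethyl nor methyl can be told from hydrogen. Trifluoromethyl alone stands apart, with a 6.7-fold higher number from compound 1 to compound 4 (0.82 log units; beyond the scatter) as its step to hydrogen, so compounds 2, 3 and 4 form one group rather than a series graded by size. Nothing given here explains that gap. From the compounds shown here alone, what remains open is whether chlorine, a nitrile or a methoxy group at this position would match compound 1 or the other three.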